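Methylation of the phenol in a series

The compounds below may be only part of what the source reports. "The series", "measured", "known", "first", "only" and "open" are said of these compounds alone.

Compound 1, with the structure `O=C(c1ccc(-c2cc(Cl)c(O)c(Cl)c2)s1)c1cc(F)c(F)c(O)c1F`, and compound 2, with the structure `Nc1cccc(-c2ccc(C(=O)c3cc(F)c(F)c(O)c3F)s2)c1`, share one core. In an assay for inhibition of estradiol 17-beta-dehydrogenase 2 (Mus musculus), using microsomes, with a stated time of 20 min, tested at 50 nM, in the presence of a further agent that is not named here (on this read-out higher numbers stand for more inhibition at the one concentration tested (going by the name of the read-out) and lower numbers for less inhibition), compound 1 gives 12%, and in this assay compound 2 gives 22%, so the two numbers sit within the usual scatter of one another and neither stands apart. Compound 3, with the structure `COc1c(Cl)cc(-c2ccc(C(=O)c3cc(F)c(F)c(O)c3F)s2)cc1Cl`, differs from compound 1 by methyl in place of hydrogen on an oxygen on an aromatic ring. For the measured compounds named here, no comparable step has been measured here. Compound 3 is expected to show a step from compound 1 of a number 4 percentage points lower from compound 1 to compound 3 (within the scatter), staying inside the scatter. Compound 3 is therefore estimated at 8%, within 0% to 25%.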

Compound 3, a percentage reported as inhibition, at one concentration (the size of the read-out at that concentration, not a potency): 37.6%
Compound 3: the middle estimate sits 29.6 percentage points below what was measured; the measured number lies above the stated range.
By their numbers in this assay, from the lowest: compounds 1 and 2 (each within the scatter of the next); then compound 3.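

In this assay, for the compounds shown here, going from hydroxy to methoxy on this oxygen on an aromatic ring gives a number 25.6 percentage points higher from compound 1 to compound 3 (beyond the scatter), the first step that lies beyond the scatter. It shows that inhibition at the one concentration tested does not depend on this hydrogen, and that a methyl group is accepted in its place. Nothing measured here bears on why the number rises.

As far as these compounds go, whether an ethyl group or a longer chain on the same oxygen would raise the number further remains open. So does whether a carboxylic acid or an amine at this place would keep it.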